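The compounds below may be only part of what the source reports. "The series", "measured", "known", "first", "only" and "open" are said of these compounds alone.

Values in a functional assay on Caco-2 cells (Homo sapiens), read by MTT assay, with a stated time of 48 h (a higher number here means a weaker inhibitor, a lower number a stronger inhibitor), so far:
- compound 1 `CCN(CC)CCCNC(=O)c1ccc(C(CC)(CC)c2ccc(OCC(=O)C(C)(C)C)c(C)c2)n1CC` gives 1000 nM
- compound 2 `CCn1c(C(=O)NCCN)ccc1C(CC)(CC)c1ccc(OCC(=O)C(C)(C)C)c(C)c1` gives 1900 nM
- compound 3 `CCOC(=O)CN(C)C(=O)c1ccc(C(CC)(CC)c2ccc(OCC(O)C(C)(C)C)c(C)c2)n1CC` gives 12200 nM

Compound 3 has the highest number of the three, beyond the scatter from both others. The next compound is compound 4 `CCn1c(C(=O)NCCCN(C)C)ccc1C(CC)(CC)c1ccc(OCC(O)C(C)(C)C)c(C)c1`, and the change from compound 3 is (3-(dimethylamino)propyl)amino in place of ((ethoxycarbonyl)methyl)(methyl)amino on a carbonyl carbon on a carbonyl carbon. Going by the values given here, the only measured step, a 1.9-fold higher number from compound 1 to compound 2 (0.28 log units; within the scatter), concerns a different replacement and does not isolate this one. Compound 3 also differs from compound 1 and compound 2 in a second place. Even so, a lower number is expected in this assay, closer to compound 1 at 1000 nM and compound 2 at 1900 nM than to compound 3. The expected step is a 4.9-fold lower number from compound 3 to compound 4 (0.69 log units; beyond the scatter) on this estimate. Compound 4 is estimated at 2500 nM with an expected range from 800 nM to 8000 nM on these few data.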

Compound 4, half-maximal inhibitory concentration: 1900 nM
Compound 4: the middle estimate sits 1.3-fold (0.12 log units) above what was measured; the measured number falls inside the stated range.
By their numbers in this assay, from the lowest: compounds 1, 2 and 4 (each within the scatter of the next); then compound 3.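

On a carbonyl carbon whose other neighbour is an aromatic carbon, the replacement of ((ethoxycarbonyl)methyl)(methyl)amino by (3-(dimethylamino)propyl)amino moves the number in this assay, with a 6.4-fold lower number from compound 3 to compound 4 (0.81 log units; beyond the scatter). Going by these compounds alone, the only earlier step, a 1.9-fold higher number from compound 1 to compound 2 (0.28 log units; within the scatter), stayed within the scatter, so this is the first single change to go beyond it. The result therefore shows that this assay can respond to the group on this carbonyl carbon.

From the compounds shown here alone, whether the lower number follows the dimethylamino end, the amide hydrogen or the loss of the ethyl ester stays open, as does how a carboxylic acid or a longer chain would read here. Any explanation of the step also stays open, as no measurement at hand bears on it.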